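A few compounds are considered here, and "the series" means these few. Any claim that something is new, unique, unknown or untested is made for them only; others in the source may bear on it.

Compound 1 `COC(=O)[C@@]1(C)CCC=C2[C@@H]1CC[C@@H](C)[C@]2(C)Cc1c[nH]c2ccc(Cl)cc12` and compound 2 `COC(=O)[C@@]1(C)CCC=C2[C@@H]1CC[C@@H](C)[C@]2(C)Cc1c[nH]c2ccc(F)cc12` share one core, while compound 3 `COC(=O)[C@@]1(C)CC[C@@H]2C3=C1CC[C@@H](C)[C@]3(C)C[C@@H]1c3cc(Cl)ccc3N[C@H]21` and compound 4 `COC(=O)[C@@]1(C)CC[C@@H]2C3=C1CC[C@@H](C)[C@]3(C)C[C@@H]1c3cc(F)ccc3N[C@H]21` share another; the difference between the two cores is not broken down here. In a functional assay on WiDr cells (Homo sapiens) for inhibition, read by sulforhodamine B assay, with a stated time of 48 h (on this read-out higher numbers stand for weaker inhibition of growth and lower numbers for stronger inhibition of growth), compound 1 gives 20000 nM. In this assay compound 2 gives 8000 nM. The change from compound 1 to compound 2 is fluoro in place of chloro on an aromatic carbon, and it made a 2.5-fold lower number from compound 1 to compound 2 (0.40 log units; beyond the scatter). In this assay compound 3 gives 48000 nM, which stands apart from the numbers of both compound 1 and compound 2.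

Compound 4 has not yet been measured. The change from compound 3 to compound 4 is fluoro in place of chloro on an aromatic carbon; it is the same kind of change as that from compound 1 to compound 2, differing only in that the aromatic carbon carrying the group is part of a fused or bridged system of five rings rather than two. Because the earlier change made a 2.5-fold lower number from compound 1 to compound 2 (0.40 log units; beyond the scatter), the step from compound 3 to compound 4 in this assay is expected to be of similar size, a 2.5-fold lower number from compound 3 to compound 4 (0.40 log units; beyond the scatter). Compound 4 is therefore estimated at 19000 nM, between 9000 nM and 40000 nM.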

Compound 4, concentration for 50% growth inhibition: 32000 nM
Compound 4: middle estimate off by 1.7-fold (0.23 log units), on the low side; low and high end bracket the measured number.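

On the core of compound 3, fluoro in place of chloro gives a 1.5-fold lower number from compound 3 to compound 4 (0.18 log units; within the scatter), so on this core the exchange does not separate the two compounds in this assay. Set beside the same exchange on the core of compound 1, the two steps cannot be told apart: the same change on two cores in this assay, a 2.5-fold lower number (0.40 log units; beyond the scatter) from compound 1 to compound 2 and a 1.5-fold lower number (0.18 log units; within the scatter) from compound 3 to compound 4, 1.7-fold (0.22 log units) apart, within the scatter of two such steps. For the compounds shown here, this shows that these four compounds give no sign of the change behaving differently from one core to the other, but it does not show that the step is the same on both, as each core contributes a single pair and only the step on the core of compound 1 lies beyond the scatter.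

The compounds shown leave open whether a hydrogen, a methoxy group or a nitrile on the same aromatic carbon would fit alongside the chloro and fluoro compounds on either core. They also leave open how a carboxylic acid in place of the methyl ester would read in this assay.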